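Cytotoxicity in the series: limits only so far

The compounds below may be only part of what the source reports. "The series", "measured", "known", "first", "only" and "open" are said of these compounds alone.

Compound 3 `CC(=O)c1cccc(-c2ccc(C(=O)N(Cc3cccc(OCCCCCC(=O)O)c3)C(C)C)cc2)c1` is compound 2 `CC(C)N(Cc1cccc(OCCCCCC(=O)O)c1)C(=O)c1ccccc1` with 3-acetylphenyl in place of hydrogen on an aromatic carbon; compound 1 `CC(C)N(Cc1cccc(OCCCCCC(=O)O)c1)C(=O)c1ccc(-c2cccc(N(C)C)c2)cc1` carries 3-(dimethylamino)phenyl on an aromatic carbon instead. In an ADME assay on HepG2 cells (Homo sapiens) for cytotoxicity, read by CellTiter-Glo and resazurin assay, with a stated time of 72 h (a higher number here means that more compound is needed for the effect, a lower number that less compound is needed), compound 3 gives > 26000 nM, which is a limit of the assay and not a number. Compound 1 gives > 26000 nM in this assay, also a limit. Compound 2 likewise gives > 26000 nM, a limit. All three values sit at the same point (the limit of > 26000 nM in this assay, at which 3 of the 3 values shown sit), so the steps a step that the two limits leave unreadable from compound 1 to compound 2, a step that the two limits leave unreadable from compound 1 to compound 3 and a step that the two limits leave unreadable from compound 2 to compound 3 cannot be read in size or direction.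

Compound 4 `CC(C)COc1cccc(-c2ccc(C(=O)N(Cc3cccc(OCCCCCC(=O)O)c3)C(C)C)cc2)c1` differs from compound 3 by isobutoxy in place of acetyl on an aromatic carbon. Among the measured compounds shown here, the steps that bear on this place are a step that the two limits leave unreadable from compound 1 to compound 3 and a step that the two limits leave unreadable from compound 2 to compound 3; both end at the limit and give no size to carry over, showing only that hydrogen, 3-(dimethylamino)phenyl and 3-acetylphenyl on this aromatic carbon all left the value at the limit. For compound 4 the expected step in this assay is therefore a step that the limit leaves unreadable from compound 3 to compound 4, that is, no change beyond the scatter and most likely another limit. Compound 4 is estimated at 30000 nM, within 15000 nM to 80000 nM.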

Compound 4, half-maximal effective concentration: > 26000 nM
Compound 4 gave a limit, no number; the forecaster's own chance of this, stated with the estimate: 85%; the middle value is on the limit's open side.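

Compound 4 sits at the same limit as compound 1, compound 2 and compound 3, so no step among these compounds can be read in size or direction: the limit of > 26000 nM in this assay, at which 4 of the 4 values shown sit.

The compounds shown leave open whether any group at this aromatic carbon gives a measurable half-maximal effective concentration in this assay, and how far apart the four compounds lie.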